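Nitro for methyl on a thiazole amide

This account rests on a few compounds, and the source may have more. Where it says the series, first, only, none or still open, it means among the compounds named here.

Measured compounds:
compound 1 `Cc1cnc(NC(=O)COc2ccc(/C=C3\SC(=O)NC3=O)cc2)s1`: < 100000 nM
compound 2 `O=C(COc1ccc(/C=C2\SC(=O)NC2=O)cc1)Nc1cccc(C(F)(F)F)c1`: 2240 nM

In a functional assay on KB cells (Homo sapiens) for cytotoxicity, read by sulforhodamine B assay, with a stated time of 48 h (on this read-out higher numbers stand for weaker inhibition of growth and lower numbers for stronger inhibition of growth), compound 1 gives only a limit, < 100000 nM, as noted in the limit of < 100000 nM in this assay, at which 1 of the 2 values shown sits. Compound 2 `O=C(COc1ccc(/C=C2\SC(=O)NC2=O)cc1)Nc1cccc(C(F)(F)F)c1` gives 2240 nM in this assay. Compound 3 `O=C(COc1ccc(/C=C2\SC(=O)NC2=O)cc1)Nc1ncc([N+](=O)[O-])s1` differs from compound 1 by nitro in place of methyl on an aromatic carbon. Among the measured compounds shown here, no measured step of this kind exists here, so the size of the step is uncertain; a modest step toward stronger inhibition of growth is expected, a step that the limit leaves unreadable from compound 1 to compound 3. Compound 3 is therefore estimated at 5000 nM, within 800 nM to 40000 nM.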

Compound 3, concentration for 50% growth inhibition: < 100000 nM
Compound 3: only a limit was reported; the forecaster's own chance of this, stated with the estimate: 25%; the middle value does not contradict the limit.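

Compound 1 and compound 3 both give only a limit, so no step from compound 1 to compound 3 can be read: the limit of < 100000 nM in this assay, at which 2 of the 3 values shown sit.

The compounds shown leave open whether nitro in place of methyl on an aromatic carbon changes inhibition of growth at all.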